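Compound 3: an expected value after the bromophenyl change

The source may report more compounds than this note shows. Statements on the series, on what has been measured and on what is new or still open speak of the compounds shown alone.

Among the measured compounds shown here, in an ADME assay on Vero cells (Chlorocebus sabaeus) for cytotoxicity, read by resazurin assay, with a stated time of 72 h (on this read-out lower numbers stand for stronger inhibition and higher numbers for weaker inhibition), compound 1 (`COc1ccc(C(=O)CCN2CCN(c3ccc(C(F)(F)F)cc3)CC2)cc1`) gives 135000 nM and compound 2 (`O=C(CCN1CCN(c2ccc(C(F)(F)F)cc2)CC1)c1ccc(Br)cc1`) gives 78800 nM in the same test, so compound 2 stands level with the only other measured compound. Compound 3 (`O=C(CCN1CCN(c2ccc(C(F)(F)F)cc2)CC1)c1ccc(F)c(Br)c1`) follows from compound 2 by one change (3-bromo-4-fluorophenyl in place of 4-bromophenyl on a carbonyl carbon), with 3-bromo-4-fluorophenyl in place of 4-bromophenyl on a carbonyl carbon. For the measured compounds named here, the one measured step (a 1.7-fold lower number from compound 1 to compound 2 (0.23 log units; within the scatter)) is the only guide, and it stays within the scatter, so no step beyond the scatter is expected. The expected change is small (a 1.1-fold lower number from compound 2 to compound 3 (0.05 log units; within the scatter)) as estimated here. In this assay compound 3 is estimated at 70000 nM (expected range 35000 nM to 140000 nM).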

Compound 3, half-maximal inhibitory concentration: 66800 nM
Compound 3: the middle estimate sits 1.0-fold (0.02 log units) above what was measured, within the range that was stated.
By their numbers in this assay, from the lowest: compounds 3, 2 and 1 (each within the scatter of the next, the first and the last beyond it).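

In this assay the step to 3-bromo-4-fluorophenyl in place of 4-bromophenyl on the carbonyl carbon is a 1.2-fold lower number from compound 2 to compound 3 (0.07 log units; within the scatter), so this position accepts the extra fluorine without a change beyond the scatter. Set against 4-methoxyphenyl, the same group gives a 2.0-fold lower number from compound 1 to compound 3 (0.31 log units; beyond the scatter), the only step here that clears the scatter, and only modestly. Nothing available explains either step. Still open, as far as these compounds go, is whether an amine or a carboxylic acid on this phenyl ring, or a longer chain at the carbonyl, would shift the number further.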